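Fluoro to bromo at an assay limit

A few compounds are considered here, and "the series" means these few. Any claim that something is new, unique, unknown or untested is made for them only; others in the source may bear on it.

Compound 1 `C=C[C@@](C)(/C=C/c1ccc(Nc2ccc(Cl)c(F)c2)cc1)CCC=C(C)C` gives > 36600 nM (a limit)
Compound 2 `C=C[C@@](C)(/C=C/c1ccc(-c2cccc(F)c2)cc1)CCC=C(C)C` gives > 36600 nM (a limit)

In an ADME assay on HEK293 cells (Homo sapiens) for cytotoxicity, with a stated time of 72 h (a higher number here means that more compound is needed for the effect, a lower number that less compound is needed), compound 2 gives > 36600 nM as a limit and not a number. Compound 3 `C=C[C@@](C)(/C=C/c1ccc(-c2cccc(Br)c2)cc1)CCC=C(C)C` carries bromo in place of fluoro on an aromatic carbon, with bromo in place of fluoro on an aromatic carbon as the count. Among the compounds with values here, the only measured step is a step that the two limits leave unreadable from compound 1 to compound 2 and gives no size. Both measured compounds rest on the limit of > 36600 nM in this assay, at which 2 of the 2 values shown sit, and offer no size to carry over. No step beyond the scatter is therefore expected. The expected step is a step that the limit leaves unreadable from compound 2 to compound 3 by this estimate. For compound 3 the estimate is 40000 nM with an expected range from 15000 nM to 80000 nM and a reading at the limit is likely.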

Compound 3, half-maximal effective concentration: > 36600 nM
Compound 3 was reported as a limit; the forecaster's own chance of this, stated with the estimate: 75%; the middle value lies beyond the limit too.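

No step can be read among compound 1, compound 2 and compound 3 in this assay, as all three rest on the same limit: the limit of > 36600 nM in this assay, at which 3 of the 3 values shown sit.

On these data alone, what concentration any of them would need for the effect stays open, and so does whether bromo and fluoro differ at all here.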